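From pyridin-2-yl to pyridin-4-yl in a growth assay

This account rests on a few compounds, and the source may have more. Where it says the series, first, only, none or still open, it means among the compounds named here.

Compound 1 `Cc1sc2nc(-c3ccncc3)c(/C=N/NC(=N)N)n2c1C`: 39800 nM
Compound 2 `N=C(N)N/N=C/c1c(-c2cc([N+](=O)[O-])c(Cl)cc2Cl)nc2sc(Cl)cn12`: 29500 nM
Compound 3 `N=C(N)N/N=C/c1c(-c2ccccn2)nc2sc(Cl)cn12`: 7940 nM

All three values come from a functional assay on renal cells (Homo sapiens) for antiproliferative activity; a higher number here means a weaker inhibitor of growth, a lower number a stronger inhibitor of growth. Here compound 3 stands lowest of the three at 7940 nM, and both other numbers lie beyond the scatter from it: compound 2 gives 29500 nM and compound 1 gives 39800 nM.

The next compound to be tested is compound 4 `N=C(N)N/N=C/c1c(-c2ccncc2)nc2sc(Cl)cn12`. It has the same atoms as compound 3, joined differently, with pyridin-4-yl in place of pyridin-2-yl on an aromatic carbon.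

Among the measured compounds shown here, no measured pair isolates this change, so the evidence is thin. For the measured compounds named here, compound 1 is the only measured compound that carries pyridin-4-yl, and it gives 39800 nM, but its core also differs from that of compound 3. That value is therefore only a weak hint. In this assay, going by the values given here, a modest step toward a higher number is expected, of a size close to the scatter, and no step at all remains possible. The expected change is a 1.9-fold higher number from compound 3 to compound 4 (0.28 log units; within the scatter). Compound 4 is estimated at 15000 nM, with an expected range from 5000 nM to 40000 nM.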

Compound 4, concentration for 50% growth inhibition: 6610 nM
Compound 4: the middle estimate sits 2.3-fold (0.36 log units) above what was measured; measured number inside the range.
By their numbers in this assay, from the lowest: compounds 4 and 3 (each within the scatter of the next); then compounds 2 and 1 (each within the scatter of the next).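

In this assay, among the compounds shown here, compounds 3 and 4 form the first pair that isolates this change, and it gives a 1.2-fold lower number from compound 3 to compound 4 (0.08 log units; within the scatter). For the compounds shown here, on this aromatic carbon of the five-membered aromatic ring with 2 nitrogen, the measurements therefore do not separate pyridin-4-yl from pyridin-2-yl, and the earlier hint from compound 1, which gives 39800 nM and also carries pyridin-4-yl, finds no support in this pair, since the core of compound 1 differs. No measurement is available that would account for this result or connect it to any property of the two groups.

The compounds shown leave open whether pyridin-3-yl or an unsubstituted phenyl ring on the same carbon would also stay within the scatter of compound 3 and compound 4. They also leave open whether the swap between pyridin-2-yl and pyridin-4-yl would give as small a step on the core of compound 1, or whether an amine or a carboxylic acid on the pyridine ring would move the number.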